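This account rests on a few compounds, and the source may have more. Where it says the series, first, only, none or still open, it means among the compounds named here.

Of the compounds shown here, three have been measured in an assay on isolated protein for inhibition of Aromatase (Homo sapiens), read by fluorescence and colorimetric assay, with a stated time of 30 min; on this read-out lower numbers stand for stronger inhibition and higher numbers for weaker inhibition. Compound 1 `N#Cc1ccc(C(c2ccc(C#N)cc2)n2cc(C3CCCCC3)nn2)cc1` gives 19300 nM. Compound 2 `N#Cc1ccc(C(c2ccc(C#N)cc2)n2cc(COc3ccc(-c4ccccc4)cc3)nn2)cc1` gives 13400 nM. Compound 3 `CCCCCCc1cn(C(c2ccccc2)c2ccccc2)nn1` gives 14800 nM, the second highest of the three numbers; its nearest neighbour is compound 2 and its furthest is compound 1, and both gaps lie within the scatter of repeated measurements. Compound 4 `c1ccc(OCc2cn(C(c3ccccc3)c3ccccc3)nn2)cc1` has not yet been measured. It differs from compound 3 in one place: phenoxy in place of pentyl on a saturated chain carbon bound to an aromatic carbon. Going by the values given here, no measured pair shows this change, so the expectation rests only on how closely the three measured compounds sit together, all at weak inhibition in this assay. Compound 4 is therefore expected to show no step beyond the scatter, a 1.1-fold lower number from compound 3 to compound 4 (0.06 log units; within the scatter). Compound 4 is estimated at 13000 nM, within a range from 5000 nM to 35000 nM.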

Compound 4, half-maximal inhibitory concentration: 31300 nM
For compound 4 the middle estimate is 2.4-fold (0.38 log units) below the measured one; low and high end bracket the measured number.
By their numbers in this assay, from the lowest: compounds 2, 3, 1 and 4 (each within the scatter of the next, the first and the last beyond it).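

In this assay, phenoxy in place of pentyl on a saturated chain carbon bound to an aromatic carbon gives a 2.1-fold higher number from compound 3 to compound 4 (0.33 log units; beyond the scatter), a modest move towards weaker inhibition. This position is therefore not indifferent to what it carries, which the closely grouped earlier numbers could not show. Nothing measured here accounts for the step.

This one pair brings in an oxygen and an aromatic ring together, leaving the share of each unresolved. From the compounds shown here alone, how an amine or a carboxylic acid would read at this place also remains open.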